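The compounds below may be only part of what the source reports. "The series", "measured", "known", "first", "only" and "open" are said of these compounds alone.

Cytotoxicity in an ADME assay on PBMC cells (Homo sapiens) for cytotoxicity, with a stated time of 5 days (on this read-out higher numbers stand for weaker inhibition and lower numbers for stronger inhibition), has been followed across a shared core that is varied only at the group on a carbon with a double bond to nitrogen. Compound 1 `c1csc(C2=NNC(c3ccc(N4CCCCC4)cc3)C2)c1` gives 20800 nM; compound 2 `Cc1ccsc1C1=NNC(c2ccc(N3CCCCC3)cc2)C1` gives 11000 nM; compound 3 `Brc1ccsc1C1=NNC(c2ccc(N3CCCCC3)cc2)C1` gives 57000 nM. Compound 3 stands highest of the three: a 2.7-fold higher number from compound 1 to compound 3 (0.44 log units; beyond the scatter) and a 5.2-fold higher number from compound 2 to compound 3 (0.71 log units; beyond the scatter) are both beyond the scatter, whereas a 1.9-fold lower number from compound 1 to compound 2 (0.28 log units; within the scatter) stays within it. Compound 4 `Brc1ccc(C2=NNC(c3ccc(N4CCCCC4)cc3)C2)s1` is the next step, the same atoms joined differently: 5-bromothiophen-2-yl in place of 3-bromothiophen-2-yl on a carbon with a double bond to nitrogen. Among the measured compounds shown here, no measured step moves a bromo group from one ring carbon to another; the two steps that bear on the question, bromo in place of hydrogen and bromo in place of methyl, show only that the bromo group, as it stands in compound 3, raises the number. With bromine retained, compound 4 is expected to stay close to compound 3, and a 1.4-fold lower number from compound 3 to compound 4 (0.15 log units; within the scatter) is expected to fall within the scatter. For compound 4 the estimate in this assay is 40000 nM, with a range from 15000 nM to 110000 nM.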

Compound 4, half-maximal inhibitory concentration: 80000 nM
Compound 4: middle estimate off by 2.0-fold (0.30 log units), on the low side; measured number inside the range.
By their numbers in this assay, from the lowest: compounds 2 and 1 (each within the scatter of the next); then compounds 3 and 4 (each within the scatter of the next).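

In this assay the change from 3-bromothiophen-2-yl to 5-bromothiophen-2-yl tests the placement of the bromo group on the ring, and a 1.4-fold higher number from compound 3 to compound 4 (0.15 log units; within the scatter) shows that the two placements cannot be told apart. The raised number is thus not tied to one ring carbon: a 3.8-fold higher number from compound 1 to compound 4 (0.59 log units; beyond the scatter) for bromo in place of hydrogen, and a 7.3-fold higher number from compound 2 to compound 4 (0.86 log units; beyond the scatter) places the 5-bromothiophen-2-yl group beyond the scatter from 3-methylthiophen-2-yl too. No measurement at hand accounts for this lack of dependence on placement.

Open, going by these compounds, is whether the higher number belongs to bromine itself or would also follow other groups on this ring. A chloro group, a nitrile or an amine in either bromo placement would separate these readings, as would a second bromo group on the ring.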